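The source may hold more compounds than are shown below. What is called first, only, known or untested is meant among the compounds shown, and "the series" means these compounds.

Among the measured compounds shown here, in a functional assay on the whole organism for inhibition, with Cavia porcellus as the target (a higher number here means that more compound is needed for the effect, a lower number that less compound is needed), compound 1 `CN(C)/C(=N\C#N)C1=CC(C)(C)Oc2ccc([N+](=O)[O-])cc21` gives 51.3 nM, the only true number so far. Compound 2 `CN(C)/C(=N\C#N)C1=CC(C)(C)Oc2ccc(S(C)(=O)=O)cc21` gives > 31600 nM, which is a limit of the assay. For the measured compounds named here, the single measured step, an at least 610-fold higher number from compound 1 to compound 2 (2.78 log units; beyond the scatter), lies on an aromatic carbon, not at the site changed in compound 3 `CN(C)/C(=N\C(N)=O)C1=CC(C)(C)Oc2ccc([N+](=O)[O-])cc21`, so it shows only that one change can move the number sharply. The change here is carbamoyl in place of cyano on a double-bonded nitrogen. A higher number is expected, though a smaller rise than the measured step, and the estimated step is a 16-fold higher number from compound 1 to compound 3 (1.19 log units; beyond the scatter). For compound 3 the expected value is 800 nM, with an estimated range of 70 nM to 10000 nM.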

Compound 3, half-maximal effective concentration: > 31600 nM
Compound 3 was reported as a limit (the forecaster's own chance of this, stated with the estimate: 20%); at least 39-fold (1.59 log units) between middle value and limit.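

On the double-bonded nitrogen, carbamoyl in place of cyano gives an at least 610-fold higher number from compound 1 to compound 3 (2.78 log units; beyond the scatter), so this second site in the series also responds sharply to a single change in this assay. The value of compound 3, > 31600 nM, is a limit. Both changes made to compound 1 now end at that same limit, and how far their steps differ cannot be read: the limit of > 31600 nM in this assay, at which 2 of the 3 values shown sit.

Open, on these data alone, is whether another group on this nitrogen, such as an acetyl or a methyl ester, would give a true number, and how that number would stand against the value of compound 1, 51.3 nM.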